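This account rests on a few compounds, and the source may have more. Where it says the series, first, only, none or still open, it means among the compounds named here.

Compound 1 `COc1ccc(/C=C/C(=O)c2ccc(OCC=C(C)C)cc2O)cc1OC` and compound 2 `COc1cc(/C=C/C(=O)c2ccc(OCC=C(C)C)cc2O)cc(OC)c1OC` share a core and are tested in an assay on isolated protein for inhibition of Polyunsaturated fatty acid 5-lipoxygenase (Homo sapiens); on this read-out lower numbers stand for stronger inhibition and higher numbers for weaker inhibition. In this assay compound 1 shows only a limit, > 100000 nM, and no number. In this assay compound 2 likewise shows only a limit, > 100000 nM. The step that the two limits leave unreadable from compound 1 to compound 2 therefore cannot be read, since both values rest at the limit of > 100000 nM in this assay, at which 2 of the 2 values shown sit. Among the compounds with values here, compound 2 thus stands at the limit of this assay, with no number of its own; the one other value shown is also a limit.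

Compound 3 `COc1cc(/C=C/C(=O)c2ccc(OCC=C(C)C)cc2OCC=C(C)C)cc(OC)c1OC` differs from compound 2 by 3-methylbut-2-en-1-yl in place of hydrogen on an oxygen on an aromatic ring. Within the data shown here, the only measured step, the one from compound 1 to compound 2, bears on a different part of the structure and is itself unreadable, so nothing measured speaks to the size or direction of the change from hydroxy to (3-methylbut-2-en-1-yl)oxy. On that basis the expected step of a number no higher from compound 2 to compound 3 (the limit leaves the size open) is essentially no step beyond the scatter, with a wide range around it. For compound 3 the estimated value in this assay is 100000 nM, expected to lie between 15000 nM and 600000 nM.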

Compound 3, half-maximal inhibitory concentration: 4000 nM
Compound 3: the middle estimate sits 25-fold (1.40 log units) above what was measured, and the stated range ends above it.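

Replacing hydroxy with (3-methylbut-2-en-1-yl)oxy at this oxygen on an aromatic ring gives, in this assay, an at least 25-fold lower number from compound 2 to compound 3 (1.39 log units; beyond the scatter), and this is the only step among the compounds shown that can be read. The step from compound 1 to compound 2, the methoxy change on an aromatic carbon, cannot be read, so the oxygen carrying the new chain is the one place here where a change in structure is seen to move the read-out. Compound 2 rests at a limit of the assay, and compound 3 is the one compound shown with a number of its own: the limit of > 100000 nM in this assay, at which 2 of the 3 values shown sit.

The compounds shown leave open whether this shift needs the 3-methylbut-2-en-1-yl group itself or would also follow from another group on the same oxygen, such as a methyl, a longer chain, or a chain ending in an amine or a carboxylic acid. They also leave open whether the extra methoxy that separates compound 2 from compound 1 makes any difference once the 3-methylbut-2-en-1-yl group is in place.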